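The source may report more compounds than this note shows. Statements on the series, on what has been measured and on what is new or still open speak of the compounds shown alone.

Working notes on the series in a toxicity assay on cells (Cricetulus griseus) for cytotoxicity, read by MTT assay, with a stated time of 72 h; on this read-out higher numbers stand for weaker inhibition and lower numbers for stronger inhibition. Compound 1 `Cc1c(C)c2c(c(C)c1OC(=O)CCC(=O)O)CCC(C)(C(=O)NC1CC(C)(C)N([O])C1(C)C)O2` returns only a limit of this assay, > 300000 nM. Compound 2 `Cc1c(C)c2c(c(C)c1OC(=O)CCC(=O)NC1CC(C)(C)N([O])C(C)(C)C1)CC[C@@](C)(CCC[C@H](C)CCC[C@H](C)CCCC(C)C)O2` likewise returns only a limit of this assay, > 300000 nM. Within the data shown here, compound 3 `Cc1c(C)c2c(c(C)c1O)CCC(C)(C(=O)NCC1CC(C)(C)N([O])C1(C)C)O2` is the one member with a number: in this assay compound 3 gives 192000 nM. Among the measured compounds shown here, no two of the three measured compounds differ in a single place, so no measured step is available, and compound 2 therefore stands simply at the limit of > 300000 nM in this assay, at which 2 of the 3 values shown sit, rather than at a number that can be compared.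

Compound 4 `Cc1c(C)c2c(c(C)c1OC(=O)CCC(=O)NC1CC(C)(C)N([O])C1(C)C)CC[C@@](C)(CCC[C@H](C)CCC[C@H](C)CCCC(C)C)O2` is not yet measured. It differs from compound 2 by a group of 10 heavy atoms (8 carbon, 1 nitrogen, 1 oxygen; one five-membered non-aromatic ring with 1 hetero atom) in place of a group of 11 heavy atoms (9 carbon, 1 nitrogen, 1 oxygen; one six-membered non-aromatic ring with 1 hetero atom), on an amide-type nitrogen. The shared core and the long chain on it are kept as in compound 2. With the change confined to the ring on the amide-type nitrogen, no step beyond the scatter of this assay is expected in either direction. Compound 4 is accordingly estimated at 350000 nM, with a range from 150000 nM to 900000 nM. The step that the limit leaves unreadable from compound 2 to compound 4 is expected to stay within the scatter, and a limit rather than a number is the more probable read-out.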

Compound 4, half-maximal inhibitory concentration: > 300000 nM
Compound 4 gave a limit, no number; the forecaster's own chance of this, stated with the estimate: 70%; the middle value does not contradict the limit.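

In this assay compound 4 gives > 300000 nM, a limit and not a number. Among these compounds, compound 2 also stands at a limit, so no step from compound 2 to compound 4 can be read. The compounds shown leave open how the five-membered and six-membered rings on the amide-type nitrogen compare in this assay.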